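Moving a Carbon Within the Chain: Straight to Branched

A few compounds are considered here, and "the series" means these few. Any claim that something is new, unique, unknown or untested is made for them only; others in the source may bear on it.

Compound 3 `CCCCC/N=C(\NC#N)Nc1cccnc1` sits in a functional assay on the whole organism (blood, strain Wistar-Okamoto) with Rattus norvegicus as the target, with a stated time of 5 days (on this read-out lower numbers stand for an effect already at smaller amounts and higher numbers for an effect only at larger amounts of compound), at 20 mg/kg. Compound 2 `CCC/N=C(\NC#N)Nc1cccnc1` gives 20 mg/kg in this assay, and the step of no change at the digits printed from compound 2 to compound 3 (within the scatter) shows that lengthening the chain at that point did nothing measurable. Compound 1 `C/N=C(\NC#N)Nc1cccnc1` yields only a limit in this assay, > 50 mg/kg. That value marks (the limit of > 50 mg/kg in this assay, at which 1 of the 3 values shown sits), so the steps of an at least 2.5-fold lower number from compound 1 to compound 2 (0.39 log units; beyond the scatter) and an at least 2.5-fold lower number from compound 1 to compound 3 (0.39 log units; beyond the scatter) are known only as minimums.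

Compound 4 `CC(C)CC/N=C(\NC#N)Nc1cccnc1` differs from compound 3 by isopropyl in place of propyl on a saturated chain carbon, two bonds along the chain from a double-bonded nitrogen. Among the compounds with values here, no measured step rearranges the chain in this way; the closest comparison is the chain extension from compound 2 to compound 3, which stayed within the scatter, and it suggests that the outer part of the chain carries little weight in this assay. The account therefore expects no step beyond the scatter, no change at the digits printed from compound 3 to compound 4 (within the scatter), for compound 4. Compound 4 is estimated to give 20 mg/kg in this assay, with a range expected from 10 mg/kg to 40 mg/kg.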

Compound 4, minimum effective dose: 20 mg/kg
Compound 4: the middle estimate sits on the measured number at the digits printed; the measured number falls inside the stated range.
By their numbers in this assay, from the lowest: compounds 2, 3 and 4 (each within the scatter of the next). At a limit, above all of these: compound 1.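

In this assay, branching at this place proves as silent as lengthening did, with no change at the digits printed from compound 3 to compound 4 (within the scatter) and no change at the digits printed from compound 2 to compound 4 (within the scatter). Within the data shown here, the earlier compounds showed only that the length of a straight chain could change without a measurable effect, whereas this result shows the same for the shape of the chain, at least for isopropyl in place of propyl. The isobutyl chain also keeps an at least 2.5-fold lower number from compound 1 to compound 4 (0.39 log units; beyond the scatter), a size known only as a minimum, the starting value being a limit of the assay: the limit of > 50 mg/kg in this assay, at which 1 of the 4 values shown sits.

Going by these compounds, whether this flat response holds for a longer chain such as octyl, a cyclohexyl ring, or a chain ending in an amine or a carboxylic acid remains open. So does branching on the saturated chain carbon bound to a double-bonded nitrogen, as a tert-butyl group would bring.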